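The compounds below may be only part of what the source reports. "The series", "measured", "known", "first", "only" and "open" are said of these compounds alone.

Measured in a functional assay on HeLa C3 cells (Homo sapiens) for cytotoxicity, read by MTT assay, with a stated time of 72 h; a lower number here means a stronger inhibitor, a higher number a weaker inhibitor:
Compound 1, `C=C(C)[C@H](CC=C(C)C)C[C@@]12C[C@@H](CC=C(C)C)C(C)(C)[C@@](CCC(C)(C)O)(C(=O)C(C(=O)c3ccc(O)c(O)c3)=C1O)C2=O`, gives 17500 nM.
Compound 2, `C=C(C)[C@H](CC=C(C)C)C[C@@]12C[C@@H](CC=C(C)C)C(C)(C)[C@@](CC(O)C(C)(C)O)(C(=O)C(C(=O)c3ccc(O)c(O)c3)=C1O)C2=O`, gives 23000 nM.
Compound 3, `C=C(C)C(O)C[C@H](C[C@@]12C[C@@H](CC=C(C)C)C(C)(C)[C@@](CC=C(C)C)(C(=O)C(C(=O)c3ccc(O)c(O)c3)=C1O)C2=O)C(=C)C`, gives 14300 nM.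

Compound 4, `C=C(C)CC[C@H](C[C@@]12C[C@@H](CC=C(C)C)C(C)(C)[C@@](CC=C(C)C)(C(=O)C(C(=O)c3ccc(O)c(O)c3)=C1O)C2=O)C(=C)C`, has not yet been measured in this assay. It is made from compound 3 by a single change: hydrogen in place of hydroxy on a saturated chain carbon bound to a double-bonded chain carbon and a saturated chain carbon. A change of the same kind, (hydrogen in place of hydroxy on a saturated chain carbon bound to two saturated chain carbons), links compound 2 to compound 1, though the place is not the same: there the carbon is bound to two saturated chain carbons, here to a double-bonded chain carbon and a saturated chain carbon. That earlier step gave a 1.3-fold lower number from compound 2 to compound 1 (0.12 log units; within the scatter). How the core of compound 3 differs from that of compound 2 is not broken down here. The three measured values all lie within the scatter of one another. For compound 4 a step of about a 1.2-fold lower number from compound 3 to compound 4 (0.08 log units; within the scatter) is expected, because a change of the same kind gave a 1.3-fold lower number from compound 2 to compound 1 (0.12 log units; within the scatter). Compound 4 is therefore estimated at 12000 nM, most likely between 6000 nM and 24000 nM.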

Compound 4, half-maximal inhibitory concentration: 12400 nM
Compound 4: middle estimate off by 1.0-fold (0.01 log units), on the low side; the range from low to high includes it.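

In this assay, putting hydrogen in place of hydroxy on a saturated chain carbon bound to a double-bonded chain carbon and a saturated chain carbon gives a 1.2-fold lower number from compound 3 to compound 4 (0.06 log units; within the scatter) and so moves the number no further than repeat measurements would. Set beside the earlier case, the change behaves alike on both cores: the same change on two cores in this assay, a 1.3-fold lower number (0.12 log units; within the scatter) from compound 2 to compound 1 and a 1.2-fold lower number (0.06 log units; within the scatter) from compound 3 to compound 4, 1.1-fold (0.06 log units) apart, within the scatter of two such steps

So in these two pairs, removing a hydroxy group left the number within the scatter. With steps this small, the pairs cannot show whether the change has any real effect, nor that it would carry to other cores in the series.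

The compounds shown leave open what an amine, a carboxylic acid or a methoxy group would do in place of this hydroxy.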